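This account rests on a few compounds, and the source may have more. Where it says the series, first, only, none or still open, it means among the compounds named here.

Measured compounds:
Compound 1, `O=C(Nc1ccc(Oc2ccnc3[nH]ccc23)c(F)c1)c1nn(-c2ccc(Cl)cc2)ccc1=O`. In a functional assay on A549 cells (Homo sapiens) for cytotoxicity, read by MTT assay, with a stated time of 72 h (on this read-out higher numbers stand for weaker inhibition and lower numbers for stronger inhibition), compound 1 gives > 60000 nM, which is a limit of the assay and not a number.
Compound 2, `O=C(Nc1ccc(Oc2ccnc3[nH]ccc23)c(F)c1)c1nn(-c2ccc(Br)cc2)ccc1=O`. In this assay compound 2 gives > 60000 nM, again a limit of the assay.

Compound 2 therefore stands at no measured number in this assay, only at a limit. Going by the values given here, both values shown sit at that same limit (the limit of > 60000 nM in this assay, at which 2 of the 2 values shown sit), so no step of known size exists among the measured compounds.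

Compound 3, `O=C(Nc1ccc(Oc2ccnc3[nH]ccc23)c(F)c1)c1nn(-c2ccccc2)ccc1=O`, is not yet measured. It differs from compound 2 in one place: hydrogen in place of bromo on an aromatic carbon. Among the compounds with values here, the only measured step that touches the same part of the molecule, a step that the two limits leave unreadable from compound 1 to compound 2, is unreadable, because both of its ends are limits. Within the data shown here, no size of step can therefore be taken from the data, in either direction.

With both measured compounds at the limit, compound 3 is expected to sit near 80000 nM, within the range 30000 nM to 300000 nM. The estimate amounts to an expected step that the limit leaves unreadable from compound 2 to compound 3, which is no change beyond the scatter.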

Compound 3, half-maximal inhibitory concentration: 56800 nM
Compound 3: the middle estimate sits 1.4-fold (0.15 log units) above what was measured; the measured number falls inside the stated range.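

Compound 3 carries a plain phenyl where compound 2 has 4-bromophenyl. In this assay, going by these compounds alone, compound 3 gives 56800 nM, the only value among the three compounds that is a number and not a limit. Taking the halogen away from this aromatic carbon gives an at least 1.0-fold lower number from compound 2 to compound 3 (0.02 log units; that floor lies within the scatter), and the same change starting from the chloro compound gives an at least 1.0-fold lower number from compound 1 to compound 3 (0.02 log units; that floor lies within the scatter). As far as these compounds go, these two steps are floors and not sizes, so they show no real gain from losing the halogen, and the true distance stays unknown because the two halogen compounds rest on a limit: the limit of > 60000 nM in this assay, at which 2 of the 3 values shown sit.

The step between the chloro and bromo compounds still cannot be read, so nothing separates these two halogens, and with only hydrogen, chloro and bromo shown, the reach of this position remains unknown. From the compounds shown here alone, it stays open whether a methoxy group, an amine or a carboxylic acid on this aromatic carbon would move the number well beyond the scatter, or whether changes elsewhere on the shared core matter more.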